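A few compounds are considered here, and "the series" means these few. Any claim that something is new, unique, unknown or untested is made for them only; others in the source may bear on it.

Measured so far:
Compound 1 `Cc1nc(N(C)C2CCCC2)nc2ccc(NC(=O)/C=C/c3ccc(Cl)cc3)cc12`: 12%
Compound 2 `Cc1nc(N2CCC(N3CCOC3=O)CC2)nc2ccc(NC(=O)/C=C/c3ccc(OC(F)(F)F)cc3)cc12`: 74%

Both were run in an ADME assay on microsomes from liver (Mus musculus) for metabolic stability, with a stated time of 30 min; a higher number here means that more of the compound is left, a lower number that less of the compound is left. Of the two numbers, compound 2 stands highest. The gap between compound 2 and compound 1 lies well beyond the usual scatter of this assay. Among the measured compounds shown here, with only two compounds on hand, nothing more general can be drawn from them.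

Compound 3 `Cc1nc(NCCNC(=O)C2CC2)nc2ccc(NC(=O)/C=C/c3ccc(OC(F)(F)F)cc3)cc12` has not yet been tested. It keeps the shared core of compound 2 and changes one group: (2-((cyclopropylcarbonyl)amino)ethyl)amino in place of 4-(2-oxo-1,3-oxazolidin-3-yl)piperidin-1-yl on an aromatic carbon. For the measured compounds named here, no measured pair shows this exact exchange, so the direction of the step has to be guessed. Since compound 2 already gives 74% in this assay, a sizeable loss is expected rather than a gain. The step of a number 29 percentage points lower from compound 2 to compound 3 (beyond the scatter) is expected to be downward and beyond the scatter. Compound 3 is estimated at 45%, within a range from 15% to 75%.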

Compound 3, percent of the compound remaining: 38%
Beside the measured number, compound 3's estimate is 7 percentage points above it, within the range that was stated.
By their numbers in this assay, from the lowest: compound 1; then compound 3; then compound 2.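

In this assay, the position on an aromatic carbon between two ring nitrogen atoms turns out to matter: putting (2-((cyclopropylcarbonyl)amino)ethyl)amino in place of 4-(2-oxo-1,3-oxazolidin-3-yl)piperidin-1-yl gives a number 36 percentage points lower from compound 2 to compound 3 (beyond the scatter). The rest of the molecule stays the same across this step, so the size of the change goes with this one exchange alone. No measurement on hand explains the drop.

The exchange replaces a piperidine carrying an oxazolidinone with an open chain ending in a cyclopropyl amide, so a single step cannot show which part of that difference counts. Going by these compounds, it stays open whether a plain piperidine, or the same ethylamino chain ending in a carboxylic acid, would sit nearer to compound 2 or to compound 3.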